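This account rests on a few compounds, and the source may have more. Where it says the series, first, only, none or still open, it means among the compounds named here.

Compound 1 `O=C(NC(=O)c1ccccc1O)c1ccc(OC(F)(F)F)cc1`: 84 ug/mL
Compound 2 `CS(=O)(=O)c1ccc(C(=O)NC(=O)c2ccccc2O)cc1`: > 100 ug/mL (a limit)
Compound 3 `COC(=O)c1ccc(C(=O)NC(=O)c2ccccc2O)cc1`: not yet measured

In an ADME assay on L6 cells (Rattus norvegicus) for cytotoxicity, read by resazurin assay, with a stated time of 72 h (on this read-out higher numbers stand for weaker inhibition and lower numbers for stronger inhibition), compound 2 gives > 100 ug/mL, which is a limit of the assay and not a number. Its standing is therefore given only by the limit of > 100 ug/mL in this assay, at which 1 of the 2 values shown sits. The next change is methoxycarbonyl in place of methylsulfonyl on an aromatic carbon, para to a large group (methoxycarbonyl in place of methylsulfonyl on an aromatic carbon). Among the compounds with values here, the one measured step that bears on it, an at least 1.1-fold higher number from compound 1 to compound 2 (0.07 log units; that floor lies within the scatter), replaced the same position and gives no size beyond the scatter. The expected change in this assay is therefore none beyond the scatter, with an estimated at least 1.1-fold lower number from compound 2 to compound 3 (0.04 log units; that floor lies within the scatter). For compound 3 the estimate is 90 ug/mL, with an expected range of 45 ug/mL to 150 ug/mL.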

Compound 3, half-maximal inhibitory concentration: 42 ug/mL
Beside the measured number, compound 3's estimate is 2.1-fold (0.33 log units) above it; the measured number lies below the stated range.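

In this assay, this position now gives a step beyond the scatter: methoxycarbonyl in place of methylsulfonyl gives an at least 2.3-fold lower number from compound 2 to compound 3 (0.37 log units; beyond the scatter). Methoxycarbonyl in place of trifluoromethoxy gives a 2.0-fold lower number from compound 1 to compound 3 (0.30 log units; within the scatter), so these two groups are not separated here. The first step has no upper size, as compound 2 stands at a limit of the assay and not at a number: the limit of > 100 ug/mL in this assay, at which 1 of the 3 values shown sits.

Still open, on these data alone, is how a carboxylic acid, an amine or a longer ester chain would read at this position. As far as these compounds go, whether the same step holds with other changes on the shared core is also open.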